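A few compounds are considered here, and "the series" means these few. Any claim that something is new, unique, unknown or untested is made for them only; others in the source may bear on it.

Measured compounds:
Compound 1, `O=C1O/C(=C\Cn2cc(-c3cc(C(F)(F)F)cc(C(F)(F)F)c3)nn2)C(OCc2ccccc2)=C1OCc1ccccc1`. In a functional assay on HeLa cells (Homo sapiens) for antiproliferative activity, read by MTT assay, with a stated time of 72 h (on this read-out higher numbers stand for weaker inhibition and lower numbers for stronger inhibition), compound 1 reaches only a limit of the assay, > 100000 nM.
Compound 2, `COc1ccc(-c2cn(C/C=C3\OC(=O)C(OCc4ccccc4)=C3OCc3ccccc3)nn2)cc1`. In this assay compound 2 likewise reaches only a limit of the assay, > 100000 nM.
Compound 3, `CC(C)(C)c1cn(C[C@H](O)[C@H]2OC(=O)C(OCc3ccccc3)=C2OCc2ccccc2)nn1`. In this assay compound 3 gives 18300 nM.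

Among the three measured compounds, compound 3 is the only one with an actual number; the other two sit at the limit of > 100000 nM in this assay, at which 2 of the 3 values shown sit, so no step between measured compounds can be read, and nothing is known about how far any single change shifts the read-out.

Compound 4, `O=C1O[C@H]([C@@H](O)Cn2cc(CCO)nn2)C(OCc2ccccc2)=C1OCc1ccccc1`, has not yet been measured. It differs from compound 3 in one place: 2-hydroxyethyl in place of tert-butyl on an aromatic carbon. The rest of the shared core, with its two benzyloxy groups and the hydroxyl-bearing side chain that carries the triazole, is unchanged.

Among the measured compounds shown here, with no measured step to lean on, the expectation for compound 4 rests on compound 3 alone. The step of a 2.2-fold higher number from compound 3 to compound 4 (0.34 log units; beyond the scatter) is expected to run toward weaker inhibition, of a size somewhat beyond the usual scatter. On that basis compound 4 is estimated at 40000 nM in this assay, within a range from 10000 nM to 150000 nM, with a real chance that the assay again reports only a limit.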

Compound 4, half-maximal inhibitory concentration: 68800 nM
The estimate for compound 4 lay 1.7-fold (0.24 log units) below the measured number; low and high end bracket the measured number.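

Among the compounds shown here, the change gives the first step in this set that can be read: in this assay, 2-hydroxyethyl in place of tert-butyl on this aromatic carbon gives a 3.8-fold higher number from compound 3 to compound 4 (0.58 log units; beyond the scatter), which means weaker inhibition. The position is therefore not silent, since a substituent with a hydrogen-bond donor and acceptor, where tert-butyl has neither, shifts the read-out by a modest but real amount while compound 4 still gives a true number. Compound 1 and compound 2 give only a limit, and the steps that involve them cannot be read, so that limit remains the ceiling for this read-out: the limit of > 100000 nM in this assay, at which 2 of the 4 values shown sit.

One step cannot separate the effect of the terminal hydroxyl from the effect of losing the branched tert-butyl, and nothing shown explains why the number rises. A plain n-butyl group would test the first of these, while a 3-hydroxypropyl chain, a primary amine or a carboxylic acid on the same carbon would show whether the weakening continues or reverses.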